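A few compounds are considered here, and "the series" means these few. Any claim that something is new, unique, unknown or untested is made for them only; others in the source may bear on it.

Compound 1 `Cn1c(-c2ccc(C#N)cc2)cnc1NC(=O)c1ncc[nH]1` gives in a toxicity assay on THP-1 cells (Homo sapiens) for inhibition (a lower number here means that less compound is tolerated, a higher number that more compound is tolerated), a value of > 100000 nM, which is a limit of the assay and not a number.
Compound 2 `Cn1c(-c2ccc(C#N)cc2)cnc1NC(=O)c1ccc(F)cc1` gives in this assay > 50000 nM, also a limit.
Compound 3 `Cn1c(-c2ccccc2F)cnc1NC(=O)c1ccc(F)cc1` gives in this assay > 100000 nM, again a limit.

Compound 1 therefore stands at the limit of > 100000 nM in this assay, at which 2 of the 3 values shown sit; no number is known for it, only that it tolerated the highest amount tested. Compound 4 `Cn1c(-c2ccccc2)cnc1NC(=O)c1ncc[nH]1` differs from compound 1 by hydrogen in place of cyano on an aromatic carbon. The two measured steps, a step that the two limits leave unreadable from compound 1 to compound 2 and a step that the two limits leave unreadable from compound 2 to compound 3, touch other parts of the shared core, and because one value sits at the limit of > 50000 nM in this assay, at which 1 of the 3 values shown sits, neither step can be read in size or direction. No step beyond the scatter is therefore expected in this assay. Compound 4 is expected to give about 150000 nM, in a range from 50000 nM to 500000 nM. The expected step that the limit leaves unreadable from compound 1 to compound 4 is estimated to stay within the scatter.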

Compound 4, half-maximal cytotoxic concentration: > 100000 nM
Compound 4 gave a limit, no number; the forecaster's own chance of this, stated with the estimate: 85%; the middle value does not contradict the limit.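

No step can be read from compound 1 to compound 4, because both give a limit of the assay and not a number: the limit of > 100000 nM in this assay, at which 3 of the 4 values shown sit.

The compounds shown leave open what concentration of any of them would reach the half-maximal cytotoxic effect in this assay.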